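This account rests on a few compounds, and the source may have more. Where it says the series, first, only, none or still open, it means among the compounds named here.

Measured so far in an assay on isolated protein for inhibition of Amine oxidase [flavin-containing] A (Rattus norvegicus); on this read-out lower numbers stand for stronger inhibition and higher numbers for weaker inhibition: compound 1 `C#CCN(C)Cc1cn(Cc2ccccc2)c2ccccc12` gives 158000 nM, and compound 2 `CCNCc1cn(Cc2ccccc2)c2ccccc12` gives 263000 nM.

Compound 2 holds the higher of the two numbers on this assay, but the step of a 1.7-fold higher number from compound 1 to compound 2 (0.22 log units; within the scatter) lies within the scatter, so the two compounds cannot be told apart on these data. Compound 3 `CC(C)NCc1cn(Cc2ccccc2)c2ccccc12` is not yet measured. It differs from compound 2 by methyl in place of hydrogen on a saturated chain carbon bound to an amine nitrogen and a saturated chain carbon; read one bond further out, ethylamino becomes isopropylamino.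

Among the measured compounds shown here, only one measured step bears on this change, a 1.7-fold higher number from compound 1 to compound 2 (0.22 log units; within the scatter), and it too alters the substituents on the amine nitrogen of the shared core. That step was within the scatter, which suggests that the amine substituent has so far moved this assay little. For the measured compounds named here, with a single, flat comparison as the only guide, a step beyond the scatter is not expected in this assay for compound 3. The estimated change is a 1.1-fold lower number from compound 2 to compound 3 (0.02 log units; within the scatter), and compound 3 is therefore expected to give about 250000 nM on this assay, with a range from 100000 nM to 600000 nM.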

Compound 3, inhibition constant: 132000 nM
Estimate against measurement, compound 3: 1.9-fold (0.28 log units) above; the range from low to high includes it.
By their numbers in this assay, from the lowest: compounds 3, 1 and 2 (each within the scatter of the next).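

In this assay, methyl in place of hydrogen on the saturated chain carbon bound to an amine nitrogen and a saturated chain carbon, the change from ethylamino to isopropylamino, gives a 2.0-fold lower number from compound 2 to compound 3 (0.30 log units; within the scatter) and so leaves compound 3 not separable from compound 2 on this read-out. Among the compounds shown here, this is the first reading of a single added methyl at this position, and the comparison of isopropylamino with methyl(propargyl)amino gives a 1.2-fold lower number from compound 1 to compound 3 (0.08 log units; within the scatter) and is equally unresolved, so the three amine substituents on the shared core cannot be told apart in this assay. No supporting data are available to account for this flat picture.

What the compounds shown leave open is whether a larger group on this carbon, such as tert-butyl or cyclohexyl, or a longer chain on the amine nitrogen would produce a step beyond the scatter. Also open, on these data alone, is whether a free primary amine or a carboxylic acid in the same place would move the number any further on the shared core.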